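The source may hold more compounds than are shown below. What is called first, only, known or untested is meant among the compounds shown, and "the series" means these compounds.

Of the compounds shown here, two built on a shared core have so far been measured in a functional assay for agonist activity at G protein-coupled receptor 88 (Homo sapiens), read by HTRF and cAMP accumulation; on this read-out lower numbers stand for an effect already at smaller amounts and higher numbers for an effect only at larger amounts of compound. Compound 1 `CC[C@H](C)[C@H](N)CN(C(=O)[C@@H]1C[C@H]1c1cccc(OC)c1)c1ccc(-c2ccccc2)cc1` gives 3000 nM in this assay, and compound 2 `CC[C@H](C)[C@H](N)CN(C(=O)[C@@H]1C[C@H]1c1ccc(F)c(F)c1)c1ccc(-c2ccccc2)cc1` gives 720 nM. Within the data shown here, of these two numbers, compound 2 holds the lower one, and the only measured step, a 4.2-fold lower number from compound 1 to compound 2 (0.62 log units; beyond the scatter), separates it from its single neighbour.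

Compound 3 `CC[C@H](C)[C@H](N)CN(C(=O)[C@@H]1C[C@H]1c1ncccn1)c1ccc(-c2ccccc2)cc1` has not yet been measured. It differs from compound 2 in one place: pyrimidin-2-yl in place of 3,4-difluorophenyl on a saturated ring carbon. Among the measured compounds shown here, the one step that bears on this change is a 4.2-fold lower number from compound 1 to compound 2 (0.62 log units; beyond the scatter), since it altered the group on that same saturated ring carbon. For the measured compounds named here, that step shows the group at this position can shift the number beyond the scatter, yet no measured compound carries a ring with hetero atoms there, so the direction is uncertain. A modest step toward a higher number is expected, a 2.8-fold higher number from compound 2 to compound 3 (0.44 log units; beyond the scatter). Compound 3 is therefore estimated at about 2000 nM, with a likely range from 500 nM to 8000 nM.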

Compound 3, half-maximal effective concentration: 130 nM
The estimate for compound 3 lay 15-fold (1.19 log units) above the measured number, outside the stated range (below it).
By their numbers in this assay, from the lowest: compound 3; then compound 2; then compound 1.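

In this assay, swapping the ring on the saturated ring carbon for pyrimidin-2-yl gives a 5.5-fold lower number from compound 2 to compound 3 (0.74 log units; beyond the scatter) and a 23-fold lower number from compound 1 to compound 3 (1.36 log units; beyond the scatter), so compound 3 holds the lowest of the three numbers, and its steps to both others lie beyond the scatter. The earlier compounds shown here compared only aromatic rings of carbon, whereas this result shows that such a ring is not needed at this position and that a smaller ring with 2 nitrogen atoms and 2 hydrogen-bond acceptors is compatible with a lower number. No measurement shown here explains the drop.

The change swaps several features at once, so the compounds shown cannot separate the role of the nitrogen atoms from that of the lost fluorine atoms or the ring size. As far as these compounds go, it also remains open whether a single ring nitrogen, as in pyridin-2-yl, or a non-aromatic ring such as morpholine, would give a similar number.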